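Adding a Second Fluoro to a Fluorinated Indane Amide

The compounds below may be only part of what the source reports. "The series", "measured", "known", "first", "only" and "open" are said of these compounds alone.

Of the compounds shown here, three with a shared core have been measured in an assay on HEK293T cells for antagonist activity at transient receptor potential cation channel subfamily M member 8 (Homo sapiens), read by fluorescence and calcium flux, with a stated time of 60 min; on this read-out higher numbers stand for weaker inhibition and lower numbers for stronger inhibition. Compound 1 `NC(=O)[C@@H](c1ccccc1)N(C(=O)c1ccccc1)[C@@H]1CCc2ccccc21` gives 270 nM. Compound 2 `NC(=O)[C@@H](c1ccccc1)N(C(=O)c1ccccc1)[C@@H]1CCc2ccc(F)cc21`, which carries a fluoro on its fused ring, gives 90 nM. Compound 3 `NC(=O)[C@@H](c1ccccc1)N(C(=O)c1ccccc1)[C@@H]1CCc2c(F)cccc21`, with a fluoro at a different position of that ring, gives 120 nM; compound 3 and compound 2 thus show numbers that lie within the usual scatter of each other, while the step of a 2.3-fold lower number from compound 1 to compound 3 (0.35 log units; beyond the scatter) stands beyond it.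

Compound 4 `NC(=O)[C@@H](c1ccccc1)N(C(=O)c1ccccc1)[C@@H]1CCc2c(F)cc(F)cc21` keeps the fluoro of compound 3 and adds one more: fluoro in place of hydrogen on an aromatic carbon. The new fluoro sits where compound 2 carries its own. Among the measured compounds shown here, two measured steps bear on this change: a 3.0-fold lower number from compound 1 to compound 2 (0.48 log units; beyond the scatter) and a 2.3-fold lower number from compound 1 to compound 3 (0.35 log units; beyond the scatter), both modest and both beyond the scatter. If the two fluoro groups acted independently, the step from compound 3 to compound 4 would resemble the step from compound 1 to compound 2; such additions often fall short of that, so a somewhat smaller step is expected. For compound 4 the estimated value in this assay is 55 nM, within a range from 25 nM to 130 nM, which means an expected step of a 2.2-fold lower number from compound 3 to compound 4 (0.34 log units; beyond the scatter).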

Compound 4, half-maximal inhibitory concentration: 100 nM
For compound 4 the middle estimate is 1.8-fold (0.26 log units) below the measured one, within the range that was stated.
By their numbers in this assay, from the lowest: compounds 2, 4 and 3 (each within the scatter of the next); then compound 1.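

In this assay, once one fluoro is in place, the second adds nothing that can be told from the scatter, whichever of the two counts as the added one: a 1.2-fold lower number from compound 3 to compound 4 (0.08 log units; within the scatter) and a 1.1-fold higher number from compound 2 to compound 4 (0.05 log units; within the scatter). The first fluoro on the core of compound 1 gave a larger step, but the gap between that step and the step to compound 4 is too small to show that the change truly works less well on a fluorinated core: the same change on two cores in this assay, a 3.0-fold lower number (0.48 log units; beyond the scatter) from compound 1 to compound 2 and a 1.2-fold lower number (0.08 log units; within the scatter) from compound 3 to compound 4, 2.5-fold (0.40 log units) apart, within the scatter of two such steps. The same caution holds for the other position: the same change on two cores in this assay, a 2.3-fold lower number (0.35 log units; beyond the scatter) from compound 1 to compound 3 and a 1.1-fold higher number (0.05 log units; within the scatter) from compound 2 to compound 4, 2.5-fold (0.40 log units) apart, within the scatter of two such steps.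

Going by these compounds, it remains open whether a chloro, a methoxy or an amine at this position would give a step beyond the scatter. On these data alone, it is also open whether the two fluoro groups would behave the same way with a change elsewhere in the molecule.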